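The source may hold more compounds than are shown below. What is called first, only, known or untested is meant among the compounds shown, and "the series" means these compounds.

Compound 3 `O=C(Nc1ccc(Oc2ccnc3[nH]ccc23)c(F)c1)c1cc(-c2ccccc2)ncn1` stands at the low end of the three numbers recorded in a functional assay on PC-3 cells (Homo sapiens) for cytotoxicity, read by MTT assay, with a stated time of 72 h; a higher number here means a weaker inhibitor, a lower number a stronger inhibitor. In this assay compound 3 gives 40 nM, compound 2 `O=C(Nc1ccc(Oc2ccnc3[nH]ccc23)cc1)c1cc(-c2ccccc2)ncn1` gives 240 nM, and compound 1 `COc1ccc(-c2ccnc(C(=O)Nc3ccc(Oc4ccnc5[nH]ccc45)cc3)n2)cc1` gives 17300 nM. Among the measured compounds shown here, the only single-point comparison available is a 6.0-fold lower number from compound 2 to compound 3 (0.78 log units; beyond the scatter), a change on the ring that carries the amide nitrogen, not on the phenyl ring where compound 4 is altered. Compound 1 carries a methoxy group on its phenyl ring but also differs from compound 2 in how the amide is attached to the shared core, so its much weaker result says little about a para substituent on its own.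

Compound 4 `Cc1ccc(-c2cc(C(=O)Nc3ccc(Oc4ccnc5[nH]ccc45)c(F)c3)ncn2)cc1` differs from compound 3 by methyl in place of hydrogen on an aromatic carbon, placed para to a large group. For the measured compounds named here, no measured step bears directly on this change, and the one recorded step concerns a different ring. A methyl group entering at this position is therefore expected to leave the number close to that of compound 3, with any shift of a 1.1-fold higher number from compound 3 to compound 4 (0.05 log units; within the scatter) regarded as likely within the scatter. Compound 4 is accordingly estimated at 45 nM in this assay, with a plausible range from 12 nM to 160 nM.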

Compound 4, half-maximal inhibitory concentration: 24900 nM
Compound 4: the middle estimate sits 550-fold (2.74 log units) below what was measured, and the stated range ends below it.
By their numbers in this assay, from the lowest: compound 3; then compound 2; then compounds 1 and 4 (each within the scatter of the next).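

The change of phenyl to 4-methylphenyl, para to a large group, gives a 620-fold higher number from compound 3 to compound 4 (2.79 log units; beyond the scatter) in this assay. Among the compounds shown here, this is the first measured step at this position, and it shows that the number here can respond very strongly to the addition of a single carbon, which is not the near-silent change that the earlier compounds left possible. The step is also far larger than the only other one recorded, a 6.0-fold lower number from compound 2 to compound 3 (0.78 log units; beyond the scatter), and it runs the opposite way, so the gain seen with fluoro on the other ring does not protect compound 4 from this large rise. Nothing in the material shown gives a reason for the size of this step.

On these data alone, with only one substituent compared directly against hydrogen at this position, it remains open whether the rise is specific to methyl or would also appear with a chlorine atom, a hydroxyl group or an amine there. As far as these compounds go, it is equally open whether methyl would have a similar effect on compound 2, which has hydrogen in place of the fluoro group of compound 3.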